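Replacing (morpholin-4-yl)carbonyl with 2-carboxyethyl on the shared core

A few compounds are considered here, and "the series" means these few. Any claim that something is new, unique, unknown or untested is made for them only; others in the source may bear on it.

Compound 1 `COc1ccc(-c2nc(CN)sc2-c2ccc(OC)cc2)cc1` gives > 100 nM
Compound 2 `CNC(=O)NCc1nc(-c2ccc(OC)cc2)c(-c2ccc(OC)cc2)s1` gives 22 nM
Compound 3 `COc1ccc(-c2nc(C(=O)N3CCOCC3)sc2-c2ccc(OC)cc2)cc1` gives < 10 nM

Compound 3 reads < 10 nM in a functional assay with Oryctolagus cuniculus as the target (a lower number here means a stronger inhibitor, a higher number a weaker inhibitor), as a limit of the assay and not a number. Compound 1 reads > 100 nM as a limit too. Going by the values given here, compound 2 gives the only true number of the three, 22 nM as measured.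

In compound 4 `COc1ccc(-c2nc(CCC(=O)O)sc2-c2ccc(OC)cc2)cc1` the change is 2-carboxyethyl in place of (morpholin-4-yl)carbonyl on an aromatic carbon and it puts 2-carboxyethyl in place of (morpholin-4-yl)carbonyl on an aromatic carbon. Among the compounds with values here, two measured steps bear on this, an at least 10-fold lower number from compound 1 to compound 3 (1.00 log units; beyond the scatter) and an at least 2.2-fold lower number from compound 2 to compound 3 (0.34 log units; beyond the scatter) and both of them brought the (morpholin-4-yl)carbonyl in. Compound 4 gives that group up, so a move back to a higher number in this assay is expected. Within the data shown here, no measured compound carries 2-carboxyethyl, so the size of the move stays uncertain. The expected change is an at least 3.0-fold higher number from compound 3 to compound 4 (0.47 log units; beyond the scatter) towards a weaker inhibitor. For compound 4 the estimate is 30 nM with an expected range from 6 nM to 150 nM as a half-maximal inhibitory concentration.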

Compound 4, half-maximal inhibitory concentration: < 100 nM
Compound 4: a limit, no number; the forecaster's own chance of this, stated with the estimate: 35%; the middle value is on the limit's open side.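

In this assay compound 4 gives < 100 nM, which is a limit of the assay and not a number. Swapping the aminomethyl group for a chain ending in a carboxylic acid gives a number no higher from compound 1 to compound 4 (the limit leaves the size open), so an acid at this position, with no ring and no nitrogen in the group, does not read as weak as the amine. The steps to compound 4 from compound 2 and from compound 3 cannot be read, and no size can be given for any of the three because the result is a limit: the limit of < 100 nM in this assay, at which 1 of the 4 values shown sits.

The shared core leaves open where 2-carboxyethyl truly falls relative to the urea of compound 2 and the morpholine amide of compound 3. It also leaves open how a shorter or longer acid chain, or the methyl ester or primary amide of this chain, would read.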